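Isobutoxy to methoxy: the untested short ether

The compounds below may be only part of what the source reports. "The series", "measured", "known", "first", "only" and "open" are said of these compounds alone.

Of the compounds shown here, two have numbers so far. In a functional assay on ACHN cells (Homo sapiens) for antiproliferative activity, read by XTT assay (on this read-out higher numbers stand for weaker inhibition and lower numbers for stronger inhibition), compound 1 `CC(C)COc1cccc2occ(Cc3coc4ccccc4c3=O)c(=O)c12` gives 1460 nM. Compound 2 `COc1ccc2c(=O)c(Cc3coc4cccc(OCC5CCCCC5)c4c3=O)coc2c1` gives 1350 nM in this assay, and the two values lie within the usual scatter of each other, so compound 1 does not stand apart from compound 2 on what is measured. Compound 3 `COc1cccc2occ(Cc3coc4ccccc4c3=O)c(=O)c12` has not yet been measured. It differs from compound 1 by hydrogen in place of isopropyl on a saturated chain carbon bound to an oxygen on an aromatic ring. Among the compounds with values here, no step between two measured compounds isolates this change, so the expectation rests on the single anchor given by compound 1 at 1460 nM and is set loosely. A step from compound 1 of a 1.7-fold higher number from compound 1 to compound 3 (0.23 log units; within the scatter) is expected, leaning toward a weaker number while possibly staying inside the scatter. The estimate for compound 3 in this assay is 2500 nM, ranging from 900 nM to 7000 nM.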

Compound 3, half-maximal inhibitory concentration: 340 nM
Compound 3: the middle estimate sits 7.4-fold (0.87 log units) above what was measured; measured number below the stated range.
By their numbers in this assay, from the lowest: compound 3; then compounds 2 and 1 (each within the scatter of the next).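

In this assay, hydrogen in place of isopropyl on a saturated chain carbon bound to an oxygen on an aromatic ring gives a 4.3-fold lower number from compound 1 to compound 3 (0.63 log units; beyond the scatter), a modest step but one beyond the scatter. Within the data shown here, this position therefore responds to what the ether carries, and the isopropyl is not required for inhibition in this cell assay, which the earlier values, with no step between them, could not show. Nothing at hand explains the step.

As far as these compounds go, how the number moves between isobutoxy and methoxy remains open, as does whether an ethoxy or propoxy chain would sit on the same line. Also open, from the compounds shown here alone, is whether a free hydroxyl in place of the methoxy would extend the change or reverse it, since this single pair gives only two points at this position.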